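The source may hold more compounds than are shown below. What is called first, only, known or untested is meant among the compounds shown, and "the series" means these compounds.

Measured compounds:
compound 1 `COc1ccc2c(=O)c(/C=C/C(=O)Nc3ccccc3)coc2c1` — > 200000 nM
compound 2 `COc1ccc2c(=O)c(/C=C/C(=O)Nc3ccccc3Cl)coc2c1` — > 200000 nM

In a functional assay on L02 cells (Homo sapiens) for inhibition, read by MTT assay, with a stated time of 48 h (on this read-out lower numbers stand for stronger inhibition and higher numbers for weaker inhibition), compound 1 gives > 200000 nM, which is a limit of the assay and not a number. Compound 2 likewise gives > 200000 nM, again only a limit. Within the data shown here, the one measured step, a step that the two limits leave unreadable from compound 1 to compound 2, chloro in place of hydrogen on an aromatic carbon, therefore has no readable size, since the limit of > 200000 nM in this assay, at which 2 of the 2 values shown sit, shows both values sitting at the same limit. Compound 1 thus stands at the limit, and nothing among the numbers shown places it more precisely.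

Compound 3 `O=C(/C=C/c1coc2cc(O)ccc2c1=O)Nc1ccccc1` differs from compound 1 by hydrogen in place of methyl on an oxygen on an aromatic ring; cut one bond further out, the change reads methoxy to hydroxy. No measured step touches this position, so the only guide is that neither shown compound reached a number in this assay. On that basis compound 3 is expected to give 250000 nM, with a range from 100000 nM to 800000 nM, most probably reported as a limit once more. The estimated step that the limit leaves unreadable from compound 1 to compound 3 is expected to stay within the scatter rather than beyond it.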

Compound 3, half-maximal inhibitory concentration: > 200000 nM
Compound 3 ended at the assay's limit (the forecaster's own chance of this, stated with the estimate: 85%); the middle value is on the limit's open side.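

No new step can be read: in this assay compound 3 gives > 200000 nM, which is a limit of the assay and not a number, and compound 1 also stands only at a limit. The compounds shown leave open what size either change would have in this assay, as none of them reaches a number: the limit of > 200000 nM in this assay, at which 3 of the 3 values shown sit.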